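Cytotoxicity notes on a trifluoromethylphenyl thiourea series

The source may hold more compounds than are shown below. What is called first, only, known or untested is meant among the compounds shown, and "the series" means these compounds.

Two members of this thiourea series have been tested in an ADME assay on MT4 cells (Homo sapiens) for cytotoxicity; a lower number here means that less compound is tolerated, a higher number that more compound is tolerated. Compound 1 `CC[C@H]1CC[C@H](c2ccc(NC(=S)Nc3cccc(C(F)(F)F)c3)cc2)CC1` gives 39000 nM in this assay, the highest of the two numbers recorded. Compound 2 `Cc1ccc(NC(=S)Nc2cccc(C(F)(F)F)c2)cc1Cl` gives 20000 nM in this assay; its gap to compound 1 is within the usual scatter, so the two compounds cannot be told apart on these data.

Compound 3 `N#Cc1ccc(NC(=S)Nc2cccc(C(F)(F)F)c2)cc1` has not yet been measured. It differs from compound 1 at one site: cyano in place of 4-ethylcyclohexyl on an aromatic carbon. For the measured compounds named here, no step between measured compounds covers a change of this kind, so the expectation rests on the narrow spread seen so far. The step of a 1.1-fold lower number from compound 1 to compound 3 (0.05 log units; within the scatter) is expected to be no larger than the scatter, without a clear direction. Compound 3 is therefore estimated at 35000 nM, with a range from 12000 nM to 100000 nM in this assay.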

Compound 3, half-maximal cytotoxic concentration: 7000 nM
Compound 3: the middle estimate sits 5.0-fold (0.70 log units) above what was measured; measured number below the stated range.
By their numbers in this assay, from the lowest: compound 3; then compounds 2 and 1 (each within the scatter of the next).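

In this assay, for the compounds shown here, this position is not indifferent to what it carries: cyano in place of 4-ethylcyclohexyl gives a 5.6-fold lower number from compound 1 to compound 3 (0.75 log units; beyond the scatter) and so provides the first step that stands clear of the scatter. Less compound is tolerated with the small cyano at this aromatic carbon than with the larger carbocyclic group, which is the only comparison across this site so far. No measurement on hand gives a reason for this step.

Going by these compounds, whether the step comes from losing 4-ethylcyclohexyl or from gaining cyano remains open, with one pair spanning this site. A hydrogen, a methoxy group, a carboxylic acid or a plain ethyl chain at the same position would help separate those two readings and show how far the trend extends.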